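Swapping the Amide Substituent: From Compound 2 to Compound 3

This account rests on a few compounds, and the source may have more. Where it says the series, first, only, none or still open, it means among the compounds named here.

Compound 1 `COC[C@@H]1CCCN1C(=O)C1CCCN1c1cc(Nc2cccc(Br)c2)ncn1`: 0%
Compound 2 `CN(CCCn1ccnc1)C(=O)[C@@H]1CCCN1c1nccc(Nc2ccccc2)n1`: 3%

In an assay on isolated protein for inhibition of tyrosine-protein kinase ZAP-70 (Homo sapiens), read by HTRF, tested at 10 uM (on this read-out lower numbers stand for less inhibition and higher numbers for more inhibition at the one concentration tested (going by the name of the read-out)), compound 1 gives 0%, and compound 2 gives 3%. Compound 2 holds the larger of the two numbers, but its gap to compound 1 lies within the usual scatter, so the two are effectively alike. Compound 3 `CN(C)CC(C)(C)CNC(=O)[C@@H]1CCCN1c1nccc(Nc2ccccc2)n1` differs from compound 2 by (2-((dimethylamino)methyl)-2-methylpropyl)amino in place of (3-(1H-imidazol-1-yl)propyl)(methyl)amino on a carbonyl carbon. With compound 2 at 3%, the step from compound 2 to compound 3 is expected to be a number 2 percentage points higher from compound 2 to compound 3 (within the scatter), nothing beyond the scatter in either direction. Compound 3 is therefore estimated at 5%, with a range from -10% to 25%.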

Compound 3, a percentage reported as inhibition, at one concentration (the size of the read-out at that concentration, not a potency): 1%
Estimate against measurement, compound 3: 4 percentage points above; measured number inside the range.
By their numbers in this assay, from the lowest: compounds 1, 3 and 2 (each within the scatter of the next).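

In this assay the change on this carbonyl carbon gives a number 2 percentage points lower from compound 2 to compound 3 (within the scatter) and so the two compounds stay alike. At this position, giving up the five-membered aromatic ring of (3-(1H-imidazol-1-yl)propyl)(methyl)amino for the open chain of (2-((dimethylamino)methyl)-2-methylpropyl)amino, which brings a hydrogen-bond donor, does not separate them on this read-out. No supporting evidence bears on this result. On these data alone, whether a carboxylic acid or a longer chain ending in a morpholine on this carbonyl carbon would give a number beyond the scatter remains open.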